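The source may report more compounds than this note shows. Statements on the series, on what has been measured and on what is new or still open speak of the compounds shown alone.

Going by the values given here, compound 1 `CON(Cc1cccs1)C(=O)COc1ccc(C)cc1` is the strongest of the two compounds measured so far: in an assay on HEK293 cells for agonist activity at transient receptor potential cation channel subfamily M member 8 (Homo sapiens), read by fluorescence and calcium flux, with a stated time of 15 min (on this read-out higher numbers stand for an effect only at larger amounts of compound and lower numbers for an effect already at smaller amounts), compound 1 gives 10 nM. Compound 2 `CCN(Cc1ccccc1)C(=O)COc1ccc(C)cc1` gives 1880 nM in this assay, a far higher number that lies well beyond the usual scatter, so compound 1 clearly acts at smaller amounts. Compound 3 `Cc1ccc(OCC(=O)N(Cc2cccs2)c2c[nH]nc2C)cc1` differs from compound 1 in one place: 3-methyl-1H-pyrazol-4-yl in place of methoxy on an amide-type nitrogen. Among the compounds with values here, no measured pair shows this change, so its effect is unknown. A loss is expected, with a step of a 20-fold higher number from compound 1 to compound 3 (1.30 log units; beyond the scatter) in this assay that goes beyond the scatter. Compound 3 is therefore estimated at 200 nM, within 20 nM to 3000 nM.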

Compound 3, half-maximal effective concentration: 0.4 nM
For compound 3 the middle estimate is 500-fold (2.70 log units) above the measured one, outside the stated range (below it).
By their numbers in this assay, from the lowest: compound 3; then compound 1; then compound 2.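

Methoxy on the amide-type nitrogen is not needed for a low number: 3-methyl-1H-pyrazol-4-yl, with more heavy atoms and a hydrogen-bond donor, gives a 25-fold lower number from compound 1 to compound 3 (1.40 log units; beyond the scatter) in this assay and so improves on an already low value. This place on the nitrogen therefore accepts a five-membered aromatic ring with 2 hetero atoms. No measurement here explains the gain.

On these data alone, whether the gain depends on the ring's methyl or on its donor hydrogen stays open. So does the outcome with a phenyl ring or a dimethylamino group on the same nitrogen.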